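This account rests on a few compounds, and the source may have more. Where it says the series, first, only, none or still open, it means among the compounds named here.

Measured in a functional assay on DU-145 cells (Homo sapiens) for inhibition, read by trypan blue exclusion, with a stated time of 96 h; on this read-out lower numbers stand for stronger inhibition of growth and higher numbers for weaker inhibition of growth:
- Compound 1 `Cc1ccc(S(=O)(=O)/C(=C/c2ccc(N(C)C)cc2)C(=O)c2ccc(Cl)cc2)cc1`: > 100000 nM (a limit of the assay)
- Compound 2 `Cc1ccc(S(=O)(=O)/C(=C/c2ccc(Br)cc2)C(=O)c2ccc(Br)cc2)cc1`: 10000 nM

Within the data shown here, compound 2, at 10000 nM, holds the only true number so far. Compound 3 `Cc1ccc(S(=O)(=O)/C(=C/c2ccc(N(C)C)cc2)C(=O)c2ccc(Br)cc2)cc1` differs from it in one place, with dimethylamino in place of bromo on an aromatic carbon, para to a large group: dimethylamino in place of bromo on an aromatic carbon. Compound 1 also carries dimethylamino, and its reading is a limit of the assay, > 100000 nM. Weaker inhibition of growth, beyond the scatter, is therefore expected, with an estimated step of a 5.0-fold higher number from compound 2 to compound 3 (0.70 log units; beyond the scatter). Compound 3 is estimated at 50000 nM, with an expected range of 15000 nM to 150000 nM.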

Compound 3, concentration for 50% growth inhibition: 50000 nM
Compound 3: the middle estimate sits on the measured number at the digits printed; low and high end bracket the measured number.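

In this assay, dimethylamino in place of bromo on the aromatic carbon now has a true number at both ends, and it weakens inhibition of growth: a 5.0-fold higher number from compound 2 to compound 3 (0.70 log units; beyond the scatter). The change of chloro to bromo on an aromatic carbon reads as an at least 2.0-fold lower number from compound 1 to compound 3 (0.30 log units; that floor lies within the scatter). On these data alone, this step starts from compound 1, whose reading is a limit of the assay, so its true size stays unknown.

As far as these compounds go, whether a plain amino group or a methoxy group at this place would stay close to compound 2 or to compound 3 remains open.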